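From Furan-2-yl to Pyridin-4-yl on the Shared Core

A few compounds are considered here, and "the series" means these few. Any claim that something is new, unique, unknown or untested is made for them only; others in the source may bear on it.

Compound 1 `Oc1cccc(-c2cc(-c3ccccc3)nc(-c3ccccc3)c2)c1` carries a phenyl group on the shared core, and in a functional assay on DU-145 cells (Homo sapiens) for cytotoxicity, read by ELISA, with a stated time of 2 days (on this read-out lower numbers stand for stronger inhibition and higher numbers for weaker inhibition), compound 1 gives 17900 nM. Compound 2 `Oc1cccc(-c2cc(-c3ccccc3)nc(-c3ccco3)c2)c1` has a furan-2-yl group in place of that phenyl, and in this assay compound 2 gives 34900 nM. Within the data shown here, of the two numbers so far, compound 2 has the highest, with compound 1 nearest a 1.9-fold higher number from compound 1 to compound 2 (0.29 log units; within the scatter).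

Compound 3 `Oc1cccc(-c2cc(-c3ccccc3)nc(-c3ccncc3)c2)c1` differs from compound 2 in one place: pyridin-4-yl in place of furan-2-yl on an aromatic carbon. Among the measured compounds shown here, the only measured step that bears on this change is a 1.9-fold higher number from compound 1 to compound 2 (0.29 log units; within the scatter), made at the same place on the core, where a six-membered ring gave way to furan-2-yl. Since that step stayed within the scatter, going back to a six-membered ring, now with one nitrogen, is expected to shift the number little, if at all. Compound 3 is therefore expected to give about 25000 nM in this assay, with a range from 9000 nM to 70000 nM, which amounts to an expected 1.4-fold lower number from compound 2 to compound 3 (0.14 log units; within the scatter).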

Compound 3, half-maximal inhibitory concentration: 18100 nM
Compound 3: the middle estimate sits 1.4-fold (0.14 log units) above what was measured, and the stated range covers the measured number.
By their numbers in this assay, from the lowest: compounds 1, 3 and 2 (each within the scatter of the next).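

With pyridin-4-yl at this position, next to the ring nitrogen, three different aromatic rings can now be compared in this assay on the shared core. The new group gives a 1.9-fold lower number from compound 2 to compound 3 (0.29 log units; within the scatter) and, set against the phenyl of the first compound, a 1.0-fold higher number from compound 1 to compound 3 (0.00 log units; within the scatter), so swapping phenyl for a six-membered ring with one nitrogen leaves the number within the scatter. Phenyl, furan-2-yl and pyridin-4-yl therefore cannot be told apart at this position, and nothing available explains this result.

Still open, on these data alone, is whether a different kind of group here, such as an amine, a carboxylic acid or a longer alkyl chain, would move the number beyond the scatter. Also open, as far as these compounds go, is whether pyridin-3-yl, with its nitrogen elsewhere in the ring, would behave like pyridin-4-yl.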